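Chloro for methyl on the aryl carbamate of a selenocyanate

This account rests on a few compounds, and the source may have more. Where it says the series, first, only, none or still open, it means among the compounds named here.

Three compounds have numbers in a functional assay on PC-3 cells (Homo sapiens) for cytotoxicity, read by MTT assay, with a stated time of 72 h; on this read-out higher numbers stand for weaker inhibition of growth and lower numbers for stronger inhibition of growth:

Compound 1, `COc1ccc(OC(=O)Nc2ccc([Se]C#N)cc2)cc1`: 7500 nM
Compound 2, `N#C[Se]c1ccc(NC(=O)Oc2ccc(F)cc2)cc1`: 11800 nM
Compound 3, `Cc1ccc(OC(=O)Nc2ccc([Se]C#N)cc2)cc1`: 7600 nM

Compound 3 holds the second highest of these three numbers. Its nearest neighbour is compound 1, the step being a 1.0-fold higher number from compound 1 to compound 3 (0.01 log units; within the scatter), and its furthest is compound 2, with a 1.6-fold lower number from compound 2 to compound 3 (0.19 log units; within the scatter). All three compounds therefore sit within the scatter of one another, and none can be called stronger or weaker than the rest.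

Compound 4, `N#C[Se]c1ccc(NC(=O)Oc2ccc(Cl)cc2)cc1`, differs from compound 3 in one place: chloro in place of methyl on an aromatic carbon. For the measured compounds named here, two measured steps bear on this change, since both alter the same position of the same ring. The exchange of methoxy for methyl gave a 1.0-fold higher number from compound 1 to compound 3 (0.01 log units; within the scatter), and the exchange of fluoro for methyl gave a 1.6-fold lower number from compound 2 to compound 3 (0.19 log units; within the scatter); the second of these involves a halogen, as the new change does. Both steps lie within the scatter. The step of a 1.1-fold higher number from compound 3 to compound 4 (0.05 log units; within the scatter) is therefore expected to stay within the scatter as well, with no direction favoured. Compound 4 is estimated at 8500 nM, in a range from 4000 nM to 18000 nM.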

Compound 4, concentration for 50% growth inhibition: 6400 nM
Beside the measured number, compound 4's estimate is 1.3-fold (0.12 log units) above it; low and high end bracket the measured number.
By their numbers in this assay, from the lowest: compounds 4, 1, 3 and 2 (each within the scatter of the next).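

In this assay, chloro now joins methyl, methoxy and fluoro at this place on the ring, para to a large group, and the change from methyl gives a 1.2-fold lower number from compound 3 to compound 4 (0.07 log units; within the scatter), while the change from methoxy gives a 1.2-fold lower number from compound 1 to compound 4 (0.07 log units; within the scatter). Even the exchange of one halogen for the other, a 1.8-fold lower number from compound 2 to compound 4 (0.27 log units; within the scatter), leaves the two compounds within the scatter, so all four groups give numbers that cannot be told apart at this position. No evidence is available that would account for these numbers.

The compounds leave open whether a group of another kind here, such as an amine, a carboxylic acid or a longer chain, would carry the number beyond the scatter. They also leave open what the carbamate and the selenocyanate contribute, since both stay the same throughout.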